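Swapping a Hydroxypropyl Sulfonamide Chain for Isobutyl

This account rests on a few compounds, and the source may have more. Where it says the series, first, only, none or still open, it means among the compounds named here.

Compound 2 `CC[C@@H]1C(=O)N(C)c2cnc(Nc3ccc(S(=O)(=O)NCCCO)cc3)nc2N1C1CCCC1` gives 8.16 nM in an assay for inhibition of serine/threonine-protein kinase PLK2 (Homo sapiens), read by FRET and Z'-LYTE, with a stated time of 1 h (on this read-out higher numbers stand for weaker inhibition and lower numbers for stronger inhibition), the lowest number among the three compounds measured. Compound 1 `CC[C@@H]1C(=O)N(C)c2cnc(Nc3ccc(S(=O)(=O)Nc4ccccc4)cc3)nc2N1C1CCCC1`, which carries a phenyl on the sulfonamide nitrogen, gives 54.4 nM in this assay, and compound 3 `CCC1C(=O)N(C)c2cnc(Nc3ccc(S(N)(=O)=O)cc3)nc2N1c1ccn(C)n1`, with an unsubstituted sulfonamide and a different group on the shared core, gives 121 nM. For the measured compounds named here, the only step between neighbours that differ in one place, a 6.7-fold lower number from compound 1 to compound 2 (0.82 log units; beyond the scatter), shows that putting the 3-hydroxypropyl chain in place of phenyl brought the number down.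

Compound 4 `CC[C@@H]1C(=O)N(C)c2cnc(Nc3ccc(S(=O)(=O)NCC(C)C)cc3)nc2N1C1CCCC1` differs from compound 2 by isopropyl in place of 2-hydroxyethyl on a saturated chain carbon bound to a sulfonamide nitrogen. The step from compound 1 to compound 2 is the one that bears on this change: compound 4, like compound 1, has no hydroxyl on the sulfonamide nitrogen, but it keeps a short chain rather than a ring. A rise in number, smaller than that earlier step, is therefore expected, namely a 3.1-fold higher number from compound 2 to compound 4 (0.49 log units; beyond the scatter) in this assay. Compound 4 is expected to give about 25 nM, within a range from 8 nM to 80 nM.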

Compound 4, half-maximal inhibitory concentration: 21.8 nM
Beside the measured number, compound 4's estimate is 1.1-fold (0.06 log units) above it; low and high end bracket the measured number.
By their numbers in this assay, from the lowest: compound 2; then compound 4; then compound 1; then compound 3.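

In this assay, the step of a 2.7-fold higher number from compound 2 to compound 4 (0.43 log units; beyond the scatter) isolates the terminal hydroxyl better than the phenyl comparison could: 3-hydroxypropyl and isobutyl are chains of equal heavy-atom count, yet isobutyl, which has no hydrogen-bond donor or acceptor, gives the higher number. The step of a 2.5-fold lower number from compound 1 to compound 4 (0.40 log units; beyond the scatter) shows that isobutyl in place of phenyl on a sulfonamide nitrogen still lowers the number, so part of the earlier gain over phenyl is seen even without the hydroxyl. No measurement here explains why either change moves the number.

Going by these compounds, whether an amine or a carboxylic acid at the chain end would match the hydroxyl remains open, as does the effect of a longer chain ending in a hydroxyl. Compound 3 differs from these compounds in more than one place, so it cannot show what an unsubstituted sulfonamide does on this core.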